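Replacing the trifluoromethyl of compound 1 with a pyrrolidine amide

The source may report more compounds than this note shows. Statements on the series, on what has been measured and on what is new or still open speak of the compounds shown alone.

The measured compounds, with their numbers in a functional assay on HEK293 cells for antagonist activity at transient receptor potential cation channel subfamily V member 1 (Rattus norvegicus), read by calcium flux; on this read-out higher numbers stand for weaker inhibition and lower numbers for stronger inhibition:
Compound 1, `FC(F)(F)c1ccc(Nc2ncnc3sc(Nc4c(Cl)cccc4Cl)nc23)cc1`, gives 3 nM.
Compound 2, `CN(c1nc2c(Nc3ccc(C(F)(F)F)cc3)ncnc2s1)c1c(Cl)cccc1Cl`, gives 540 nM.
Compound 3, `N#Cc1cc(Cl)c(Nc2nc3c(Nc4ccc(C(F)(F)F)cc4)ncnc3s2)c(Cl)c1`, gives 53 nM.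

Compound 1 stands lowest of the three in this assay; its nearest neighbour is compound 3, and the step is an 18-fold higher number from compound 1 to compound 3 (1.25 log units; beyond the scatter), while the farthest is compound 2, reached by a 180-fold higher number from compound 1 to compound 2 (2.26 log units; beyond the scatter). Both measured steps therefore run away from compound 1, and both are large.

Compound 4, `O=C(c1ccc(Nc2ncnc3sc(Nc4c(Cl)cccc4Cl)nc23)cc1)N1CCCC1`, has not yet been measured. It differs from compound 1 in one place: (pyrrolidin-1-yl)carbonyl in place of trifluoromethyl on an aromatic carbon. Neither measured step touches this position. Going by the values given here, the step to compound 2 alters a nitrogen on an aromatic ring, and the step to compound 3 adds a cyano to the dichlorophenyl ring; what they show is only that the shared core of compound 1 has so far not tolerated change well. The exchange of trifluoromethyl for (pyrrolidin-1-yl)carbonyl is a larger alteration than either, at a position for which there is no comparison at all.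

For compound 4 the account therefore expects a step of a 10-fold higher number from compound 1 to compound 4 (1.00 log units; beyond the scatter) in this assay, a weakening, with wide uncertainty. The estimate for compound 4 is 30 nM, in a range from 4 nM to 300 nM.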

Compound 4, half-maximal inhibitory concentration: > 5000 nM
Compound 4 ended at the assay's limit; the forecaster's own chance of this, stated with the estimate: 5%; at least 160-fold (2.22 log units) between middle value and limit.
By their numbers in this assay, from the lowest: compound 1; then compound 3; then compound 2. At a limit, above all of these: compound 4.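

In this assay, going by these compounds alone, the exchange at this position gives an at least 1600-fold higher number from compound 1 to compound 4 (3.22 log units; beyond the scatter), the first measured change on the ring that carries the trifluoromethyl, whereas the steps to compound 2 and compound 3 lie elsewhere in the molecule. This position is therefore not a free site: (pyrrolidin-1-yl)carbonyl, which brings a five-membered non-aromatic ring and a hydrogen-bond acceptor, gives a larger step than either the methyl on the nitrogen or the cyano on the dichlorophenyl ring. The reading for compound 4 is a limit and not a number, and the full size of its step stays unknown: the limit of > 5000 nM in this assay, at which 1 of the 4 values shown sits.

The compounds shown do not separate the part played by the carbonyl from that of the pyrrolidine ring or from the loss of trifluoromethyl itself, a question on which a dimethylamide, a chlorine or a tert-butyl group at this position would bear. From the compounds shown here alone, it also stays open whether any group other than trifluoromethyl at this position can come close to compound 1 at 3 nM.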